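The source may report more compounds than this note shows. Statements on the series, on what has been measured and on what is new or still open speak of the compounds shown alone.

Notes on the series. Compound 1, `CS(=O)(=O)Oc1c(C(=O)NCc2ccc(F)cc2)nc(Br)c2cccnc12`, carries a (methylsulfonyl)oxy group on the shared core. In a functional assay on HCT-116 cells (Homo sapiens) for cytotoxicity, read by MTT assay, with a stated time of 72 h (a higher number here means a weaker inhibitor, a lower number a stronger inhibitor), compound 1 gives only a limit, > 20000 nM, which is the limit of > 20000 nM in this assay, at which 1 of the 3 values shown sits. Compound 3, `C[C@H](NC(=O)c1nc(Br)c2cccnc2c1N[C@H]1CC[C@H](N)CC1)c1ccc(F)cc1`, likewise gives only a limit in this assay, > 10000 nM, which is the limit of > 10000 nM in this assay, at which 1 of the 3 values shown sits. Compound 2, `N[C@H]1CC[C@H](Nc2c(C(=O)NCc3ccc(Oc4ccccc4)cc3)nc(Br)c3cccnc23)CC1`, has no result in this assay, reported as "not determined" (no result reported). Among the compounds with values here, compound 1 therefore stands at a limit, one further value is also a limit, and one entry carries no number at all; no step between two measured numbers exists in this set, and no ordering among the three can be drawn.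

Compound 4, `NCCCCCCNc1c(C(=O)NCc2ccc(F)cc2)nc(Br)c2cccnc12`, differs from compound 1 by (6-aminohexyl)amino in place of (methylsulfonyl)oxy on an aromatic carbon. Compound 3 also carries an amine-bearing substituent on the shared core and reached only the limit > 10000 nM. With both measured values sitting at limits, the step from compound 1 to compound 4 is expected to be an at least 1.3-fold lower number from compound 1 to compound 4 (0.12 log units; that floor lies within the scatter), that is, none beyond the scatter in either direction. For compound 4 the estimate in this assay is 15000 nM, within a range from 5000 nM to 40000 nM, with a substantial chance that only a limit is reported.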

Compound 4, half-maximal inhibitory concentration: 7000 nM
Estimate against measurement, compound 4: 2.1-fold (0.33 log units) above; the measured number falls inside the stated range.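

At this aromatic carbon, para to a bromo group, (6-aminohexyl)amino in place of (methylsulfonyl)oxy gives in this assay an at least 2.8-fold lower number from compound 1 to compound 4 (0.45 log units; beyond the scatter). Within the data shown here, compound 4 is the first compound in this set with a measured number rather than a limit, 7000 nM, so a change at this position can move the read-out in this assay beyond the scatter. The size of the step remains only a floor, since its starting value is a limit of the assay: the limit of > 20000 nM in this assay, at which 1 of the 4 values shown sits.

The compounds shown do not separate the contribution of the terminal amine from that of the hexyl chain, and do not show whether the nitrogen attached to the aromatic carbon matters on its own; a plain hexylamino group, a shorter aminoalkyl chain, or a carboxylic acid at the end of the same chain would address these points. Among these compounds, they also leave open whether the step carries over to other amide substituents on the shared core, as no second pair differing only at this position is available.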